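Notes on one kinase series

A few compounds are considered here, and "the series" means these few. Any claim that something is new, unique, unknown or untested is made for them only; others in the source may bear on it.

Measured so far:
compound 1 `Cc1cc(C(=O)O)ccc1CN1CCC[C@H](O[C@H](CO)c2cc(Cl)cc(Cl)c2)[C@@H]1c1ccc(F)cc1`: "nd" (no result reported) (no number reported)
compound 2 `O=C(O)c1ccc(CN2CCC[C@H](O[C@H](CO)c3cc(Cl)cc(Cl)c3)[C@@H]2c2ccccc2)c([N+](=O)[O-])c1`: 13000 nM
compound 3 `Nc1cc(C(=O)O)ccc1CN1CCC[C@H](O[C@H](CO)c2cc(Cl)cc(Cl)c2)[C@@H]1c1ccccc1`: 168000 nM

In an assay on isolated protein for activation of cGMP-dependent protein kinase 1 (Homo sapiens), read by ADP-Glo, with stated times of 30 min and 2 h (a higher number here means that more compound is needed for the effect, a lower number that less compound is needed), compound 3 gives the highest of the two numbers reported. Going by the values given here, its nearest neighbour is compound 2, and the only measured step in the set is a 13-fold higher number from compound 2 to compound 3 (1.11 log units; beyond the scatter), so a single change on the aromatic ring already moves the number far beyond the scatter.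

Compound 4 `Cc1cc(C(=O)O)ccc1C(=O)N1CCC[C@H](O[C@H](CO)c2cc(Cl)cc(Cl)c2)[C@@H]1c1ccccc1` differs from compound 3 as follows: a group of 12 heavy atoms (9 carbon, 3 oxygen; one six-membered aromatic ring of carbon only) in place of a group of 11 heavy atoms (8 carbon, 1 nitrogen, 2 oxygen; one six-membered aromatic ring of carbon only), on an amine nitrogen in a ring

Among the compounds with values here, no measured step covers this change directly. The step from compound 2 to compound 3 only shows that the ring substituent matters strongly, and the amino group that accompanied the highest number is absent from compound 4; compound 1, which carries the same methyl-bearing ring as compound 4 with the benzyl link, has no number. As far as these compounds go, the link to the ring nitrogen, a carbonyl in compound 4, is untested. The expectation is therefore a number lower than that of compound 3 but with a wide range, since the direction rests on one step. For compound 4 the estimate is 50000 nM, between 8000 nM and 300000 nM, which means an expected step of a 3.4-fold lower number from compound 3 to compound 4 (0.53 log units; beyond the scatter).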

Compound 4, half-maximal effective concentration: > 200000 nM
Compound 4 gave a limit, no number; the forecaster's own chance of this, stated with the estimate: 25%; at least 4.0-fold (0.60 log units) between middle value and limit.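

In this assay compound 4 gives > 200000 nM, which is a limit of the assay and not a number. The step reads as an at least 1.1-fold higher number from compound 3 to compound 4 (0.07 log units; that floor lies within the scatter), so exchanging 2-amino-4-carboxybenzyl on the amine nitrogen in a ring for a group with a carbonyl link and a methyl in place of the amino group gives no number lower than that of the amino compound, and this position is shown to tolerate no simple gain from losing the amino group. The reading of this pair ends at the top of the measured range: the limit of > 200000 nM in this assay, at which 1 of the 4 values shown sits.

The step changes the link and the ring substituent together, so the compounds shown do not separate the share of the carbonyl from that of the amino group, and compound 1, which keeps the benzyl link with the methyl, has no number and also carries a fluorine on its phenyl group. Also open, as far as these compounds go, is how the series reads with a sulfonyl link or an ethylene chain on the ring nitrogen, or with a tetrazole in place of the carboxylic acid.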